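The source may report more compounds than this note shows. Statements on the series, on what has been measured and on what is new or still open speak of the compounds shown alone.

Among the compounds with values here, in a functional assay on A549 cells (Homo sapiens) for antiproliferative activity, read by XTT assay, with a stated time of 24 h (on this read-out lower numbers stand for stronger inhibition and higher numbers for weaker inhibition), compound 1 `Fc1ccc(C2CC(c3ccc(Cl)s3)=NN2c2nc(-c3ccc(Cl)cc3)cs2)cc1` gives 125 ug/mL, the higher of the two numbers so far, while compound 2 `Cc1ccc(C2=NN(c3nc(-c4ccc([N+](=O)[O-])cc4)cs3)C(c3ccc(F)cc3)C2)s1` gives 16.7 ug/mL, a gap beyond the usual scatter. Compound 1 is therefore the weaker inhibitor of the pair. Compound 3 `N#Cc1ccc(-c2csc(N3N=C(c4ccc(Cl)s4)CC3c3ccc(F)cc3)n2)cc1` keeps the rest of compound 1 and changes one place: cyano in place of chloro on an aromatic carbon, para to a large group, which turns 4-chlorophenyl into 4-cyanophenyl (cyano in place of chloro on an aromatic carbon). Within the data shown here, no two measured compounds differ in just one place, so no measured step speaks directly to this change. Compound 2, at 16.7 ug/mL, differs from compound 1 in more than one place and offers only a weak hint toward lower numbers. In this assay, a small expected move toward stronger inhibition, about the size of the scatter, is a 1.9-fold lower number from compound 1 to compound 3 (0.28 log units; within the scatter). The estimated value for compound 3 is 65 ug/mL, with a range from 20 ug/mL to 180 ug/mL.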

Compound 3, half-maximal inhibitory concentration: > 500 ug/mL
Compound 3: no number, only a limit (the forecaster's own chance of this, stated with the estimate: 8%); at least 7.6-fold (0.88 log units) between middle value and limit.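

In this assay, putting cyano in place of chloro on this aromatic carbon, para to a large group, gives an at least 4.0-fold higher number from compound 1 to compound 3 (0.60 log units; beyond the scatter) and so moves the series toward weaker inhibition. Within the data shown here, this is the one direct reading of a single change so far, and it shows that this place on the ring is sensitive to what it carries, even in a compound that was already weak. On these data alone, compound 3 gives > 500 ug/mL which is a limit and not a number, so the full size of the step stays unknown: the limit of > 500 ug/mL in this assay, at which 1 of the 3 values shown sits.

As far as these compounds go, whether a methoxy group or an amine at this place would fall nearer to chloro or to cyano remains open. A single step also cannot tell whether this change would act the same way in the different setting of compound 2.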